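The compounds below may be only part of what the source reports. "The series", "measured", "known", "first", "only" and "open" are said of these compounds alone.

Measured compounds in a functional assay for activation of Alpha-1B adrenergic receptor (Homo sapiens), read by calcium flux; on this read-out higher numbers stand for an effect only at larger amounts of compound and lower numbers for an effect already at smaller amounts:
compound 1 `c1coc(-c2ccccc2OCC2=NCCN2)c1`, compound 1 gives 10 nM;
compound 2 `c1ccc(-c2ccsc2)c(OCC2=NCCN2)c1`, compound 2 gives 15.9 nM;
compound 3 `c1ccc(-c2ncc[nH]2)c(OCC2=NCCN2)c1`, for compound 3 only a limit is known, < 100000 nM.

Compound 3 thus stands at the limit (the limit of < 100000 nM in this assay, at which 1 of the 3 values shown sits); no number for it exists. Going by the values given here, the only readable step in this assay is a 1.6-fold higher number from compound 1 to compound 2 (0.20 log units; within the scatter). The steps a step that the limit leaves unreadable from compound 1 to compound 3 and a step that the limit leaves unreadable from compound 2 to compound 3 cannot be sized. Compound 4 `Cc1ccoc1-c1ccccc1OCC1=NCCN1` differs from compound 3 by 3-methylfuran-2-yl in place of 1H-imidazol-2-yl on an aromatic carbon. The change brings back a furan ring like that of compound 1, carrying an added methyl; compound 1 and compound 2 sit within the scatter of each other. Compound 4 is therefore expected close to those two, estimated at 15 nM, within 4 nM to 60 nM. The expected step that the limit leaves unreadable from compound 3 to compound 4 is not readable against a number, since compound 3 carries the limit (the limit of < 100000 nM in this assay, at which 1 of the 3 values shown sits).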

Compound 4, half-maximal effective concentration: < 100000 nM
Compound 4 ended at the assay's limit; the forecaster's own chance of this, stated with the estimate: 10%; the middle value is on the limit's open side.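

In this assay, going by these compounds alone, compound 4 gives < 100000 nM, which is a limit and not a number, so no step linking compound 4 to compound 1, compound 2 or compound 3 can be read. Still open, on these data alone, is how far the methyl in place of hydrogen moves compound 4 from compound 1, and whether compound 3 and compound 4 differ at all.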